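Removing a methyl from an aromatic nitrogen

This account rests on a few compounds, and the source may have more. Where it says the series, first, only, none or still open, it means among the compounds named here.

Compound 1 `Cn1cc(-c2nn(C(C)(C)C)c3ncnc(N)c23)c2ccccc21` is the weaker of the two measured compounds. In a functional assay on NCI-H460 cells (Homo sapiens) for antiproliferative activity, with a stated time of 72 h (on this read-out lower numbers stand for stronger inhibition and higher numbers for weaker inhibition), compound 1 gives 73900 nM, while compound 2 `CC(C)(CO)Cn1nc(-c2c[nH]c3ccccc23)c2c(N)ncnc21` gives 14000 nM, a gap beyond the scatter; the two compounds differ in more than one place, so these two values are all that can be said of that pair. Compound 3 `CC(C)(C)n1nc(-c2c[nH]c3ccccc23)c2c(N)ncnc21` keeps the core of compound 1 and changes only one spot: hydrogen in place of methyl on an aromatic nitrogen. Among the measured compounds shown here, compound 2 carries a hydrogen at that same nitrogen, though its other substituent also differs, so no measured step isolates this change. Compound 3 is expected to give a somewhat lower number than compound 1, a step of a 2.5-fold lower number from compound 1 to compound 3 (0.39 log units; beyond the scatter) in this assay, though the uncertainty is wide. Compound 3 is estimated at 30000 nM, within a range from 8000 nM to 100000 nM.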

Compound 3, half-maximal inhibitory concentration: 4000 nM
Beside the measured number, compound 3's estimate is 7.5-fold (0.88 log units) above it, outside the stated range (below it).
By their numbers in this assay, from the lowest: compound 3; then compound 2; then compound 1.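

In this assay, hydrogen in place of methyl on the aromatic nitrogen gives an 18-fold lower number from compound 1 to compound 3 (1.27 log units; beyond the scatter), so a single carbon at this spot, two ring bonds from the ring atom that bears the large group, makes a large difference and the free nitrogen is clearly favoured here. The second substituent also counts: tert-butyl in place of 2-(hydroxymethyl)-2-methylpropyl gives a 3.5-fold lower number from compound 2 to compound 3 (0.54 log units; beyond the scatter), a modest step where the methyl change was a large one. Nothing available explains why removing the methyl has so large an effect.

From the compounds shown here alone, at the ring nitrogen only hydrogen and methyl can be compared, so it remains open how an ethyl group or a longer chain would fare there. Going by these compounds, it is equally open how a chain ending in an amine or a carboxylic acid would compare with tert-butyl on the other aromatic nitrogen.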